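The source may report more compounds than this note shows. Statements on the series, on what has been measured and on what is new or still open speak of the compounds shown alone.

Measured compounds and their values:

Compound 1, `O=C(CSc1nc2ccc(NC(=O)c3ccc(Cl)cc3)cc2s1)NCc1ccc(Cl)cc1`, in a functional assay on HepG2 cells (Homo sapiens) for cytotoxicity, read by MTT assay, with a stated time of 48 h (on this read-out lower numbers stand for stronger inhibition and higher numbers for weaker inhibition), gives 17800 nM.
Compound 2, `O=C(CSc1nc2ccc(NC(=O)c3ccccc3)cc2s1)NCc1ccc(Cl)cc1`, gives 30100 nM.
Compound 3, `COc1ccc(CNC(=O)CSc2nc3ccc(NC(C)=O)cc3s2)cc1`, gives 11200 nM.

Compound 2 stands at the highest of the three numbers. Among the compounds with values here, its nearest neighbour is compound 1, and the one step that can be read between single-point neighbours is a 1.7-fold higher number from compound 1 to compound 2 (0.23 log units; within the scatter), produced by hydrogen in place of chloro on an aromatic carbon. Compound 3 lies furthest from compound 2, and that gap is beyond the scatter, but compound 3 differs from compound 2 in more than one place, so nothing more than the two values themselves can be said of it.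

The next compound is compound 4, `O=C(CSc1nc2ccc(NC(=O)c3ccccc3)cc2s1)NCc1ccccc1`. It differs from compound 2 by hydrogen in place of chloro on an aromatic carbon. Within the data shown here, the only measured step that bears on this change is a 1.7-fold higher number from compound 1 to compound 2 (0.23 log units; within the scatter), the same kind of exchange on a different aromatic ring, and it stayed within the scatter. The account therefore expects no step beyond the scatter for compound 4, with at most a slight drift towards a higher number. The estimate for compound 4 is 36000 nM, in a range from 15000 nM to 85000 nM, which would mean an expected step of a 1.2-fold higher number from compound 2 to compound 4 (0.08 log units; within the scatter).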

Compound 4, half-maximal inhibitory concentration: 34200 nM
Beside the measured number, compound 4's estimate is 1.1-fold (0.02 log units) above it; measured number inside the range.
By their numbers in this assay, from the lowest: compounds 3, 1, 2 and 4 (each within the scatter of the next, the first and the last beyond it).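

In this assay, taking the chloro off the 4-chlorobenzyl group of compound 2 gives a 1.1-fold higher number from compound 2 to compound 4 (0.06 log units; within the scatter) and so leaves compound 4 indistinguishable from compound 2. Until now, this exchange had been read only on the other chlorinated ring, as a 1.7-fold higher number from compound 1 to compound 2 (0.23 log units; within the scatter), so the result adds a second site, para to a large group on the benzylamino side, where chloro and hydrogen cannot be told apart in this read-out. No accompanying measurement bears on this result.

As far as these compounds go, the steps from compound 3, which gives 11200 nM and differs from the others in more than one place, cannot be read, so what its acetyl and methoxy groups each contribute remains open. Also open, from the compounds shown here alone, is whether anything other than hydrogen or chloro at this position, such as an amine or a carboxylic acid, would move the number beyond the scatter, and whether removing both chloro groups, as compound 4 does relative to compound 1, means anything more than the two printed values show.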